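Extending the saturated chain beyond compound 3

The source may hold more compounds than are shown below. What is called first, only, known or untested is meant among the compounds shown, and "the series" means these compounds.

Compound 1 (`CCCCCCCn1cc(COC[C@@H]2OC[C@H](N)[C@@H]2O)nn1`), compound 2 (`CCCCCCCCn1cc(COC[C@@H]2OC[C@H](N)[C@@H]2O)nn1`) and compound 3 (`CCCCCCCCCn1cc(COC[C@@H]2OC[C@H](N)[C@@H]2O)nn1`) share one core and differ only in the length of their saturated chain. In a functional assay on MCF7 cells (Homo sapiens) for antiproliferative activity, read by MTT assay, with a stated time of 48 h (on this read-out lower numbers stand for stronger inhibition and higher numbers for weaker inhibition), compound 1 gives > 128000 nM as a limit of the assay, not as a number. Among the measured compounds shown here, compound 2 gives 28100 nM and compound 3 gives 12400 nM as the lowest number measured so far.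

The change to compound 4 (`CCCCCCCCCCn1cc(COC[C@@H]2OC[C@H](N)[C@@H]2O)nn1`) is this (methyl in place of hydrogen on a saturated chain carbon, nine bonds along the chain from an aromatic nitrogen): methyl in place of hydrogen on a saturated chain carbon, nine bonds along the chain from an aromatic nitrogen. Seven bonds along the chain, the same replacement gave an at least 4.5-fold lower number from compound 1 to compound 2 (0.65 log units; beyond the scatter) in a step that starts from a limit. Eight bonds along the chain, it gave a 2.3-fold lower number from compound 2 to compound 3 (0.36 log units; beyond the scatter) as the only such step between two true numbers, so it is the closer guide.

A modest further fall in this assay is therefore expected, though two steps cannot show how far the trend runs. The expected change is a 2.1-fold lower number from compound 3 to compound 4 (0.33 log units; beyond the scatter) in the same direction. Compound 4 is estimated at 5800 nM with an expected range from 2500 nM to 13000 nM for its measurement.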

Compound 4, half-maximal inhibitory concentration: 9640 nM
The estimate for compound 4 lay 1.7-fold (0.22 log units) below the measured number, within the range that was stated.
By their numbers in this assay, from the lowest: compounds 4 and 3 (each within the scatter of the next); then compound 2. At a limit, above all of these: compound 1.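

In this assay, methyl in place of hydrogen on a saturated chain carbon, nine bonds along the chain from an aromatic nitrogen, gives a 1.3-fold lower number from compound 3 to compound 4 (0.11 log units; within the scatter), so compound 3 and compound 4 cannot be told apart, unlike the pair that carries the same change on the shortest chain: the same change on two cores in this assay, an at least 4.5-fold lower number (0.65 log units; beyond the scatter) from compound 1 to compound 2 and a 1.3-fold lower number (0.11 log units; within the scatter) from compound 3 to compound 4, at least 3.5-fold (0.54 log units) apart, beyond the scatter of two such steps. Over more than one added carbon the chain length still tells, with a 2.9-fold lower number from compound 2 to compound 4 (0.46 log units; beyond the scatter) for ethyl in place of hydrogen, eight bonds along the chain from an aromatic nitrogen, and an at least 13-fold lower number from compound 1 to compound 4 (1.12 log units; beyond the scatter) for propyl in place of hydrogen, seven bonds along the chain from an aromatic nitrogen. The second of these steps starts from a limit of the assay and not from a number: the limit of > 128000 nM in this assay, at which 1 of the 4 values shown sits.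

The compounds shown leave open whether a longer chain would give a number that stays level, falls or rises. They also leave open what an amine or a carboxylic acid on a saturated chain carbon would do.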